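The compounds below may be only part of what the source reports. "The series", "measured", "known", "first", "only" and "open" are said of these compounds alone.

Values so far in a functional assay on SMMC-7721 cells (Homo sapiens) for inhibition, read by CCK-8 assay, with a stated time of 72 h, tested at 2 uM; on this read-out lower numbers stand for less inhibition of growth and higher numbers for more inhibition of growth at the one concentration tested:
- compound 1 `Nc1ccccc1NC(=O)/C=C/c1ccc(CSc2ccc(Cl)cc2)cc1` gives 15.2%
- compound 2 `COc1ccc(SCc2ccc(C(=O)Nc3ccccc3N)cc2)cc1` gives 33.1%
- compound 3 `Nc1ccccc1NC(=O)/C=C/c1ccc(CSc2ccc(F)cc2)cc1` gives 18.3%

Compound 2 has the highest of these three numbers, and compound 3 and compound 1 both lie lower by more than the scatter. Compound 4 `Cc1ccc(SCc2ccc(C(=O)Nc3ccccc3N)cc2)cc1` has not yet been measured in this assay and differs from compound 2 in one place only. The change is methyl in place of methoxy on an aromatic carbon and reads in words as methyl in place of methoxy on an aromatic carbon, or 4-methoxyphenyl to 4-methylphenyl.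

Going by the values given here, only one measured step bears on this change, and only loosely: a number 3.1 percentage points higher from compound 1 to compound 3 (within the scatter) for fluoro in place of chloro on an aromatic carbon. That step swaps different groups on the core of compound 1, not the core of compound 2, and no swap of methoxy for methyl has been measured in this series. Among the compounds with values here, with that single small step as the only guide, no move beyond the scatter is expected in this assay and the data give no firm direction. The expected step is a number 3.1 percentage points lower from compound 2 to compound 4 (within the scatter) and is estimated to stay within the usual scatter. For compound 4 the estimate is 30% with an expected range from 17% to 43% on this read-out.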

Compound 4, percent growth inhibition at one concentration: 25.1%
Estimate against measurement, compound 4: 4.9 percentage points above; the range from low to high includes it.
By their numbers in this assay, from the lowest: compounds 1, 3, 4 and 2 (each within the scatter of the next, the first and the last beyond it).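

In this assay, going by these compounds alone, the step of a number 8 percentage points lower from compound 2 to compound 4 (within the scatter) is the first direct reading at this position, an aromatic carbon para to a large group, and on this evidence methoxy and methyl cannot be told apart there. Methoxy brings one more heavy atom and a hydrogen-bond acceptor that methyl lacks, yet this difference in counts does not produce a step beyond the scatter at the one concentration tested, and the earlier step of a number 3.1 percentage points higher from compound 1 to compound 3 (within the scatter) on the core of compound 1 could not show this because it concerned fluoro and chloro. The two steps together show only that neither of these two swaps on an aromatic carbon separates its pair of compounds, and nothing available explains the size of the new step.

As far as these compounds go, whether an amine, a carboxylic acid or a longer chain such as ethoxy at this position would give a step beyond the scatter from compound 2 remains open. Also open, from the compounds shown here alone, is whether methyl in place of methoxy would read the same way on the core of compound 1 or at other concentrations.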